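A few compounds are considered here, and "the series" means these few. Any claim that something is new, unique, unknown or untested is made for them only; others in the source may bear on it.

Measured so far in an assay for inhibition of Nicotinamide phosphoribosyltransferase (Homo sapiens), read by mass spectrometry, with stated times of 15 min and 30 min; a lower number here means a stronger inhibitor, a higher number a weaker inhibitor:
compound 1, `O=C(NCc1ccc(S(=O)(=O)c2ccccc2C(F)(F)F)cc1)c1cc2cnccc2[nH]1`, gives 24 nM.
compound 2, `O=C(NCc1ccc(S(=O)(=O)c2cccc(C(F)(F)F)c2)cc1)c1cc2cnccc2[nH]1`, gives 8 nM.
compound 3, `Cc1cccc(S(=O)(=O)c2ccc(CNC(=O)c3cc4cnccc4[nH]3)cc2)c1`, gives 8 nM.

All three share one core and differ only in the ring attached to the sulfonyl sulfur. Compound 3 stands level with compound 2, and the two sit together at the lowest numbers of the three; compound 1 is the furthest away, and the step of a 3.0-fold lower number from compound 1 to compound 3 (0.48 log units; beyond the scatter) is beyond the scatter. Compound 4, `O=C(NCc1ccc(S(=O)(=O)c2ccc(F)cc2)cc1)c1cc2cnccc2[nH]1`, is not yet measured. It differs from compound 3 in one place: 4-fluorophenyl in place of 3-methylphenyl on a sulfonyl sulfur.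

Two kinds of measured step bear on this. The steps of a 3.0-fold lower number from compound 1 to compound 2 (0.48 log units; beyond the scatter) and a 3.0-fold lower number from compound 1 to compound 3 (0.48 log units; beyond the scatter) show that moving the substituent around the ring on the sulfonyl sulfur can shift the number beyond the scatter. The step of no change at the digits printed from compound 2 to compound 3 (within the scatter) shows that swapping methyl for trifluoromethyl on the same carbon leaves the number unchanged. Going by the values given here, no measured compound carries its substituent where compound 4 carries its fluorine, so the direction of this move is not set by the data. The measured ring variations span only a small range, so compound 4 is expected to land near compound 3, with a step of a 1.5-fold higher number from compound 3 to compound 4 (0.18 log units; within the scatter) that may fall within the scatter. Compound 4 is therefore estimated at 12 nM, with a range of 4 nM to 36 nM.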

Compound 4, half-maximal inhibitory concentration: 17 nM
For compound 4 the middle estimate is 1.4-fold (0.15 log units) below the measured one; the range from low to high includes it.
By their numbers in this assay, from the lowest: compounds 2 and 3 (each within the scatter of the next); then compounds 4 and 1 (each within the scatter of the next).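

In this assay, 4-fluorophenyl on the sulfonyl sulfur gives a 2.1-fold higher number from compound 3 to compound 4 (0.33 log units; beyond the scatter) and a 2.1-fold higher number from compound 2 to compound 4 (0.33 log units; beyond the scatter) with both steps beyond the scatter, so the 3-methylphenyl and 3-(trifluoromethyl)phenyl rings are not interchangeable with every other substituted phenyl ring here. Going by these compounds alone, the third step, a 1.4-fold lower number from compound 1 to compound 4 (0.15 log units; within the scatter) and within the scatter, leaves the 4-fluorophenyl and 2-(trifluoromethyl)phenyl rings indistinguishable, and across these four compounds the two rings named with a 3 give the lower numbers, with no compound going against this. No measurement shown explains why these rings differ.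

Each step to compound 4 changes both the identity of the substituent and its place on the ring, so the effect of fluorine itself cannot be separated from the effect of where it sits; a 3-fluorophenyl or a 4-methylphenyl ring would pull the two apart. Also open is how this position responds to a group of a different kind on the ring, such as an amine or a carboxylic acid, since the substituents shown are only methyl, trifluoromethyl and fluorine.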